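A few compounds are considered here, and "the series" means these few. Any claim that something is new, unique, unknown or untested is made for them only; others in the source may bear on it.

- Compound 1 `Cc1cc(CCC(=O)O)ccc1-c1noc(-c2ccc(OC(C)C)c(C(F)(F)F)c2)n1`: 1.1 h
- Compound 2 `Cc1cc(CCC(=O)O)ccc1-c1noc(-c2ccc(OC(C)C)c(Cl)c2)n1`: 0.8 h

In an in vivo ADME assay on the whole organism (strain Sprague-Dawley) for metabolic stability, with Rattus norvegicus as the target (a lower number here means that the compound disappears faster, a higher number that the compound lasts longer), compound 2 gives 0.8 h, which lies within the scatter of compound 1 at 1.1 h. Compound 3 `Cc1cc(CCC(=O)O)ccc1-c1noc(-c2ccc(OC(C)C)c(C#N)c2)n1` has cyano in place of chloro on an aromatic carbon, ortho to an isopropoxy group (cyano in place of chloro on an aromatic carbon). Within the data shown here, only one measured step bears on this change: a 1.4-fold lower number from compound 1 to compound 2 (0.14 log units; within the scatter), with chloro in place of trifluoromethyl on an aromatic carbon. Among the measured compounds shown here, no measured compound carries cyano, so the evidence is thin, and no change beyond the scatter is expected. The estimated step is a 1.1-fold lower number from compound 2 to compound 3 (0.06 log units; within the scatter). For compound 3, the expected half-life is 0.7 h, with an estimated range from 0.35 h to 1.4 h.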

Compound 3, half-life: 0.7 h
Compound 3: the middle estimate sits on the measured number at the digits printed; low and high end bracket the measured number.
By their numbers in this assay, from the lowest: compounds 3, 2 and 1 (each within the scatter of the next).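

In this assay, the position ortho to an isopropoxy group now holds three groups that the numbers do not separate: cyano gives a 1.1-fold lower number from compound 2 to compound 3 (0.06 log units; within the scatter) and also a 1.6-fold lower number from compound 1 to compound 3 (0.20 log units; within the scatter) when set against trifluoromethyl. Cyano, with its triple bond and hydrogen-bond acceptor, thus keeps the half-life within the scatter of both earlier groups. Nothing measured here speaks to the cause of these numbers. The compounds shown leave open whether an amine or a methoxy group at this position would also stay within that scatter. They also leave open how the half-life responds to changes elsewhere on the shared core.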